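Chloro to hydrogen: compound 1 to compound 4

The compounds below may be only part of what the source reports. "The series", "measured", "known", "first", "only" and "open" are said of these compounds alone.

compound 1 `Clc1cccc(/N=N/N2CCCC2)c1`: > 100000 nM (a limit)
compound 2 `Fc1ccc(F)c(/N=N/c2ccc(NC[C@@H]3CCCN4CCCC[C@H]34)c3c2CCCC3)c1`: 38000 nM
compound 3 `c1ccc(/N=N/c2ccc(NC[C@@H]3CCCN4CCCC[C@H]34)c3c2CCCC3)cc1`: > 100000 nM (a limit)

In an ADME assay on BHK-21 cells (Mesocricetus auratus) for cytotoxicity, read by MTT assay, with a stated time of 96 h (a lower number here means that less compound is tolerated, a higher number that more compound is tolerated), compound 1 gives > 100000 nM, a limit and not a number, and it stands at the limit of > 100000 nM in this assay, at which 2 of the 3 values shown sit. Compound 4 `c1ccc(/N=N/N2CCCC2)cc1` carries one change, (hydrogen in place of chloro on an aromatic carbon), that is, hydrogen in place of chloro on an aromatic carbon. Within the data shown here, the only measured step that bears on this is an at least 2.6-fold higher number from compound 2 to compound 3 (0.42 log units; beyond the scatter), with phenyl in place of 2,5-difluorophenyl on a double-bonded nitrogen, on another core. That step also removes halogen and runs toward more compound tolerated, so no fall is expected here, and a second reading at the limit is likely. The step expected is a step that the limit leaves unreadable from compound 1 to compound 4. For compound 4 the estimate is 120000 nM, with an expected range from 50000 nM to 300000 nM.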

Compound 4, half-maximal cytotoxic concentration: >= 100000 nM
Compound 4 ended at the assay's limit; the forecaster's own chance of this, stated with the estimate: 80%; the middle value lies beyond the limit too.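

Compound 1 and compound 4 both sit at a limit of this assay, so no step can be read between them. As far as these compounds go, whether hydrogen in place of chloro on an aromatic carbon changes tolerance at all remains open.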